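The source may report more compounds than this note shows. Statements on the series, on what has been measured and on what is new or still open speak of the compounds shown alone.

Of the compounds shown here, three built on one shared core have been tested in a functional assay on the whole organism (strain albino) for inhibition, with Rattus norvegicus as the target, read by paw edema, with stated times of 1 h and 3 h, at a dose of 100 mg/kg by the oral route; on this read-out lower numbers stand for a weaker effect and higher numbers for a stronger effect at the one dose given. Compound 2 `N#Cc1c(Nc2ccccc2)nc(SCC(=O)Nn2c(COc3ccc(Cl)cc3Cl)nc3ccccc3c2=O)nc1-c1ccccc1` gives 78.1% in this assay, the highest of the three numbers shown. Compound 1 `N#Cc1c(Cl)nc(SCC(=O)Nn2c(COc3ccc(Cl)cc3Cl)nc3ccccc3c2=O)nc1-c1ccc(Cl)cc1` gives 68.4%, which sits within the scatter of the number for compound 2. For the measured compounds named here, compound 3 `N#Cc1c(Nc2ccc(Cl)cc2)nc(SCC(=O)Nn2c(COc3ccc(Cl)cc3Cl)nc3ccccc3c2=O)nc1-c1ccccc1` gives 59.7%, and the only measured single step, a number 18.4 percentage points lower from compound 2 to compound 3 (beyond the scatter), lies beyond the scatter. Compound 4 `N#Cc1c(Nc2ccccc2)nc(SCC(=O)Nn2c(COc3ccc(Cl)cc3Cl)nc3ccccc3c2=O)nc1-c1ccc(Cl)cc1` has not yet been measured. It differs from compound 2 by chloro in place of hydrogen on an aromatic carbon. The measured step from compound 2 to compound 3 is likewise a chloro in place of hydrogen on an aromatic carbon, though on a different ring, and it lowered the read-out by a modest amount. Going by the values given here, compound 1 carries the same 4-chlorophenyl that compound 4 would carry, and its number is close to that of compound 2, but compound 1 differs from compound 2 in more than one place, so no single step can be drawn from it. Weighing both, a small drop is expected for this assay, and the step of a number 12.1 percentage points lower from compound 2 to compound 4 (beyond the scatter) is the estimate. Compound 4 is therefore expected to give 66%, within a range from 52% to 80%.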

Compound 4, a percentage reported as inhibition, in the whole organism at one dose (the size of the read-out at that dose, not a potency): 56.1%
The estimate for compound 4 lay 9.9 percentage points above the measured number; measured number inside the range.
By their numbers in this assay, from the lowest: compounds 4, 3, 1 and 2 (each within the scatter of the next, the first and the last beyond it).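

In this assay, for the compounds shown here, replacing phenyl with 4-chlorophenyl on the shared core gives a number 22 percentage points lower from compound 2 to compound 4 (beyond the scatter), the first single-place reading at this position. Together with a number 18.4 percentage points lower from compound 2 to compound 3 (beyond the scatter), it shows that chloro in place of hydrogen on an aromatic carbon lowered the number on both of the aromatic rings tested, so the drop seen earlier was not confined to the anilino ring. Going by these compounds alone, with the 4-chlorophenyl group held constant, a number 12.3 percentage points lower from compound 1 to compound 4 (beyond the scatter) adds a first single-place reading at the carbon that carries chloro in compound 1 and anilino in compound 4, showing that the read-out also responds to the group at that second position.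

On these data alone, whether a fluoro, methyl or methoxy group in place of this chloro would lower the number in the same way remains open, as does whether a morpholine or piperazine amine at the anilino position would behave as anilino does. The compounds shown also come with no measurement that gives a reason for either drop.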